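The compounds below may be only part of what the source reports. "The series", "measured", "known", "first", "only" and "open" are said of these compounds alone.

Compound 1 `COc1cc(/C=C/C(=O)/C=C/c2cccc3ccccc23)ccc1OCc1cn(CCCCCOc2cc(=O)oc3ccccc23)nn1` has been measured in a functional assay on HCT-116 cells (Homo sapiens) for inhibition, read by sulforhodamine B assay, with a stated time of 48 h, tested at 50 uM (on this read-out higher numbers stand for more inhibition of growth at the one concentration tested and lower numbers for less inhibition of growth), where compound 1 gives 42%. Within the data shown here, the only comparison available is compound 2 `COc1cc(/C=C/C(=O)/C=C/c2ccco2)ccc1OCc1cn(CCCOc2cc(=O)oc3ccccc23)nn1`, which gives 51%. These two numbers lie within the usual scatter of each other, so neither compound can be ranked above the other.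

Compound 3 `COc1ccc(/C=C/C(=O)/C=C/c2ccc(OCc3cn(CCCCCOc4cc(=O)oc5ccccc45)nn3)c(OC)c2)cc1` differs from compound 1 in one place: 4-methoxyphenyl in place of naphthalen-1-yl on a double-bonded chain carbon bound to a double-bonded chain carbon. Among the measured compounds shown here, no measured pair shows this change on its own, so the data offer no direct guide to its effect. However, compound 2, at 51%, differs from compound 1 in more than one place and still stays within the scatter of it. No shift beyond the scatter is therefore expected in this assay. The estimated step, a number 4 percentage points higher from compound 1 to compound 3 (within the scatter), is small. For compound 3 the expected value is 46%, with an estimated range of 30% to 62%.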

Compound 3, percent growth inhibition at one concentration: 35%
Estimate against measurement, compound 3: 11 percentage points above, within the range that was stated.
By their numbers in this assay, from the lowest: compounds 3, 1 and 2 (each within the scatter of the next, the first and the last beyond it).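

In this assay, putting 4-methoxyphenyl in place of naphthalen-1-yl on a double-bonded chain carbon bound to a double-bonded chain carbon gives a number 7 percentage points lower from compound 1 to compound 3 (within the scatter). Among these compounds, this pair is the first to isolate a single change at this position, and it shows that going from two six-membered aromatic rings of carbon only to one such ring, with one hydrogen-bond acceptor added, does not move the read-out beyond the usual scatter. Nothing at hand links this result to any property of either group.

Going by these compounds, whether an amine or a carboxylic acid at this position would give a step beyond the scatter remains open. So does the effect of the chain joining the triazole-bearing part to the rest of the molecule when it alone is changed.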